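Triazole aryl methylation in the free-phenol ketone series

The source may report more compounds than this note shows. Statements on the series, on what has been measured and on what is new or still open speak of the compounds shown alone.

Two compounds have been run in a functional assay on SMMC-7721 cells (Homo sapiens) for cytotoxicity, read by MTT assay, with a stated time of 4 days; on this read-out lower numbers stand for stronger inhibition and higher numbers for weaker inhibition. Compound 1 `C=C1C[C@]23C[C@@]1(O)CC[C@H]2c1ccc(OS(=O)(=O)c2ccc(C)cc2)c(C)c1[C@@H]3Cn1cc(-c2ccc(Br)cc2)nn1` carries a tosylated phenol and a bromophenyl on the triazole. In this assay compound 1 gives > 20000 nM, which is a limit of the assay and not a number. Compound 2 `Cc1c(O)ccc2c1[C@H](Cn1cc(-c3ccccc3)nn1)[C@@]13CC(=O)[C@@](C)(CC[C@@H]21)C3` keeps the free phenol and the ketone and bears a plain phenyl on the triazole. In this assay compound 2 gives > 20000 nM, again a limit and not a measured number. Among the measured compounds shown here, compound 2 thus stands at the limit of > 20000 nM in this assay, at which 2 of the 2 values shown sit, and no step between measured compounds exists. Compound 3 `Cc1ccc(-c2cn(C[C@H]3c4c(ccc(O)c4C)[C@@H]4CC[C@@]5(C)C[C@]43CC5=O)nn2)cc1` differs from compound 2 by methyl in place of hydrogen on an aromatic carbon. With both measured values at the limit, the step is expected to be none beyond the scatter, a step that the limit leaves unreadable from compound 2 to compound 3. Compound 3 is estimated at 25000 nM, with a range from 8000 nM to 80000 nM, and most likely again only a limit.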

Compound 3, half-maximal inhibitory concentration: > 20000 nM
Compound 3: only a limit was reported (the forecaster's own chance of this, stated with the estimate: 80%); the middle value lies beyond the limit too.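

No step can be read from compound 2 to compound 3: both values are limits of the assay and not numbers, and the change from phenyl to 4-methylphenyl stays unsized. The compounds shown leave open whether this methyl alters cytotoxicity at all.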